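This account rests on a few compounds, and the source may have more. Where it says the series, first, only, none or still open, it means among the compounds named here.

In a functional assay on CAL-51 cells (Homo sapiens) for antiproliferative activity, read by luminescence and CellTiter-Glo, with a stated time of 3 days (a lower number here means a stronger inhibitor, a higher number a weaker inhibitor), the measured compounds are:
compound 1 `COc1cc(C(=O)N(C)C)ccc1Nc1nc(OC(C)C)c2cc[nH]c2n1`, which gives 1270 nM;
compound 2 `COc1cc(C(=O)N(C)C)ccc1Nc1nc(O[C@H]2CC[C@](C)(O)CC2)c2cc[nH]c2n1`, which gives 69 nM;
compound 3 `COc1cc(N2CCC(C)(O)CC2)ccc1Nc1nc(O[C@H]2CCOC(C)(C)C2)c2cc[nH]c2n1`, which gives 71 nM.

Compound 3 stands second highest of the three numbers; its value and that of compound 2 lie within the scatter of each other, while compound 1 sits well above both. Compound 4 `COc1cc(N2CCN(C3COC3)CC2)ccc1Nc1nc(O[C@H]2CCOC(C)(C)C2)c2cc[nH]c2n1` differs from compound 3 in one place: 4-(oxetan-3-yl)piperazin-1-yl in place of 4-hydroxy-4-methylpiperidin-1-yl on an aromatic carbon. Among the measured compounds shown here, the only measured step, an 18-fold lower number from compound 1 to compound 2 (1.26 log units; beyond the scatter), changes the group on the oxygen, not the group on the aromatic carbon, so it does not bear on this change. For the measured compounds named here, compounds 2 and 3 differ in two places, and their values show only that a different group on that carbon can go with a similar number. No step beyond the scatter is therefore expected. Compound 4 is estimated at 80 nM, from 30 nM to 250 nM. The expected step is a 1.1-fold higher number from compound 3 to compound 4 (0.05 log units; within the scatter).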

Compound 4, half-maximal inhibitory concentration: 84 nM
Compound 4: middle estimate off by 1.1-fold (0.02 log units), on the low side, and the stated range covers the measured number.
By their numbers in this assay, from the lowest: compounds 2, 3 and 4 (each within the scatter of the next); then compound 1.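

In this assay, replacing 4-hydroxy-4-methylpiperidin-1-yl with 4-(oxetan-3-yl)piperazin-1-yl gives a 1.2-fold higher number from compound 3 to compound 4 (0.07 log units; within the scatter) and so leaves the number within the scatter. Among the compounds shown here, this is the first change made in this one place alone, and it shows that this aromatic carbon can carry either of these two different groups, including the larger one without the hydroxy group, with similar results. Nothing available explains why the number holds. As far as these compounds go, whether a carboxylic acid or a simple amine on this carbon would also hold the number remains open.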